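Methylsulfanyl Replaces Dimethylamino at the Aromatic Position

The source may report more compounds than this note shows. Statements on the series, on what has been measured and on what is new or still open speak of the compounds shown alone.

Compound 1 `CNc1ccc2c(c1)N(S(C)(=O)=O)CC2CCl` and compound 2 `CN(C)c1ccc2c(c1)N(S(C)(=O)=O)CC2CCl` share one core and differ only in the group on the aromatic ring. In a functional assay on EMT6 cells (Mus musculus) for cytotoxicity, with a stated time of 4 h (a higher number here means a weaker inhibitor, a lower number a stronger inhibitor), compound 1 gives 13000 nM, and compound 2 gives 20000 nM. Within the data shown here, the single measured step, a 1.5-fold higher number from compound 1 to compound 2 (0.19 log units; within the scatter), lies within the scatter, so compound 2 stands at the higher of the two numbers without being separated from compound 1. Compound 3 `CSc1ccc2c(c1)N(S(C)(=O)=O)CC2CCl` keeps the core and alters the same position: methylsulfanyl in place of dimethylamino on an aromatic carbon. Among the measured compounds shown here, the only step that bears on this exchange is a 1.5-fold higher number from compound 1 to compound 2 (0.19 log units; within the scatter), which also reworked the group at this aromatic carbon and moved this assay by no more than the scatter. On that basis compound 3 is expected to show no step beyond the scatter, the expected step being a 1.3-fold lower number from compound 2 to compound 3 (0.12 log units; within the scatter). The estimated value for compound 3 is 15000 nM, with a range from 5000 nM to 45000 nM.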

Compound 3, half-maximal inhibitory concentration: > 200000 nM
Compound 3 was reported as a limit; the forecaster's own chance of this, stated with the estimate: 10%; at least 13-fold (1.12 log units) between middle value and limit.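

In this assay, compound 3 is read only as a limit and not as a number: the limit of > 200000 nM in this assay, at which 1 of the 3 values shown sits.

Methylamino and dimethylamino at this aromatic carbon were not separated, with a 1.5-fold higher number from compound 1 to compound 2 (0.19 log units; within the scatter), but the position does respond to the group placed there: methylsulfanyl in place of dimethylamino gives an at least 10-fold higher number from compound 2 to compound 3 (1.00 log units; beyond the scatter), and methylsulfanyl in place of methylamino gives an at least 15-fold higher number from compound 1 to compound 3 (1.18 log units; beyond the scatter). Among these three compounds, then, the two groups joined through nitrogen stay together, and the group joined through sulfur, compound 3, is the weakest.

The compounds shown leave open whether the loss of the nitrogen or the arrival of the sulfur counts here, which a plain amino group, a methoxy group or a bare hydrogen at this carbon would help to separate. As far as these compounds go, how far compound 3 lies past its limit also stays open.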